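A few compounds are considered here, and "the series" means these few. Any claim that something is new, unique, unknown or untested is made for them only; others in the source may bear on it.

Compound 2 `CC(=O)c1ccc(N2CCN(C(=O)c3oc(C)nc3-c3ccccc3)CC2)cc1` is the starting point of this account. In a functional assay on HL-60 cells (Homo sapiens) for inhibition, read by MTT assay, with a stated time of 72 h (a higher number here means a weaker inhibitor, a lower number a stronger inhibitor), compound 2 gives "not active" (no number reported), so there is no single number to place it on; compound 1 `COc1ccc(-c2nc(C)oc2C(=O)N2CCN(c3cccc(Cl)c3)CC2)cc1OC`, which in this assay also gives "not active" (no number reported), stands in the same position without a number. Among the compounds with values here, the only compound with a numerical reading is compound 3 `CCc1nc(-c2ccc(C(C)C)cc2)c(C(=O)N2CCN(c3cccc(OC)c3)CC2)o1`, which in this assay gives 887 nM.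

Compound 4 `Cc1nc(-c2ccccc2)c(C(=O)N2CCN(c3cc(Cl)cc(Cl)c3)CC2)o1` differs from compound 2 in one place: 3,5-dichlorophenyl in place of 4-acetylphenyl on an amine nitrogen in a ring. Within the data shown here, no measured pair shows the effect of such a change on its own, so any expectation about the size or direction of the step in this assay rests on the three compounds described, two of which return no number at all. Given that compound 2 gives "not active" (no number reported) in this assay, the step is expected to remain small and to leave compound 4 a weak inhibitor, with a fair chance that it too returns no number. For compound 4 the half-maximal inhibitory concentration in this assay is estimated at 6000 nM, expected to lie between 1000 nM and 40000 nM.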

Compound 4, half-maximal inhibitory concentration: 41.8 nM
Beside the measured number, compound 4's estimate is 140-fold (2.16 log units) above it; measured number below the stated range.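

Within the data shown here, compound 2 has no single number in this assay, so no step to compound 4 can be read. The compounds shown leave open how much the 3,5-dichlorophenyl group alone contributes to the reading of compound 4. No evidence at hand bears on this result.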